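The source may report more compounds than this note shows. Statements on the series, on what has been measured and on what is new or still open speak of the compounds shown alone.

Compound 1 `COc1ccc(-c2cc3ccccc3nc2/C=C/C(=O)c2c(OC)cccc2OC)cc1` is, on the numbers gathered so far, the compound with the lowest reading: in a functional assay on H184B5F5/M10 cells (Homo sapiens) for antiproliferative activity, read by XTT assay, with a stated time of 72 h (on this read-out higher numbers stand for weaker inhibition and lower numbers for stronger inhibition), compound 1 gives 4470 nM. Two other compounds share its core and differ only in the group attached to the carbonyl carbon. Compound 2 `COc1ccc(-c2cc3ccccc3nc2/C=C/C(=O)c2ccc(N)cc2)cc1` gives 9290 nM, and compound 3 `COc1ccc(-c2cc3ccccc3nc2/C=C/C(=O)c2ccsc2)cc1` gives 6390 nM. Exchanging the 2,6-dimethoxyphenyl group gave a 2.1-fold higher number from compound 1 to compound 2 (0.32 log units; beyond the scatter) and a 1.4-fold higher number from compound 1 to compound 3 (0.16 log units; within the scatter), so swapping this group has so far moved the number only a little, and never downward.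

Compound 4 `COc1ccc(-c2cc3ccccc3nc2/C=C/C(=O)c2sccc2N)cc1` is not yet measured. Relative to compound 1 the change is 3-aminothiophen-2-yl in place of 2,6-dimethoxyphenyl on a carbonyl carbon. Both earlier exchanges at this carbonyl carbon bear on it: a five-membered ring entering there gave a step within the scatter, and an amino-bearing ring gave a modest rise. A modest rise is therefore expected here too, estimated as a 1.6-fold higher number from compound 1 to compound 4 (0.19 log units; within the scatter). Compound 4 is expected to give about 7000 nM in this assay, with a range from 3500 nM to 14000 nM.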

Compound 4, half-maximal inhibitory concentration: > 10000 nM
Compound 4: only a limit was reported (the forecaster's own chance of this, stated with the estimate: 5%); middle value at least 1.4-fold (0.15 log units) from the limit.
By their numbers in this assay, from the lowest: compounds 1, 3 and 2 (each within the scatter of the next, the first and the last beyond it). At a limit, above all of these: compound 4.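

Compound 4 carries a limit and not a number: the limit of > 10000 nM in this assay, at which 1 of the 4 values shown sits. Even so, putting 3-aminothiophen-2-yl on the carbonyl carbon gives an at least 2.2-fold higher number from compound 1 to compound 4 (0.34 log units; beyond the scatter), which shows that a single ring holding both a five-membered aromatic ring and an amino group does not bring the reading in this assay down to that of the 2,6-dimethoxyphenyl group. The other two comparisons, an at least 1.5-fold higher number from compound 3 to compound 4 (0.19 log units; that floor lies within the scatter) and an at least 1.0-fold higher number from compound 2 to compound 4 (0.03 log units; that floor lies within the scatter), have floors within the scatter, so they do not show that this group is worse than thiophen-3-yl or 4-aminophenyl.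

Going by these compounds, how far the reading of compound 4 lies past its limit remains unknown. A plain thiophen-2-yl group without the amine, or a plain phenyl ring, could help separate the part played by the ring from that of the amine or methoxy groups.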